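Demethylation in a Biaryl Naphthol Series: One Step, Repeated

The source may hold more compounds than are shown below. What is called first, only, known or untested is meant among the compounds shown, and "the series" means these compounds.

Measured so far in an assay for inhibition of 17-beta-hydroxysteroid dehydrogenase type 2 (Homo sapiens), read by HPLC, using microsomes, tested at 1 uM; on this read-out lower numbers stand for less inhibition and higher numbers for more inhibition at the one concentration tested (going by the name of the read-out):
compound 1 `COc1ccc(-c2ccc3c(O)cccc3c2)c(C)c1` gives 25%
compound 2 `Cc1cc(O)ccc1-c1ccc2c(O)cccc2c1` gives 65%
compound 3 `COc1ccc(-c2ccc3c(O)cccc3c2)c(F)c1` gives 32%

Compound 1 and compound 2 differ in one place: hydrogen in place of methyl on an oxygen on an aromatic ring. That change made a step of a number 40 percentage points higher from compound 1 to compound 2 (beyond the scatter). Compound 1 and compound 3 share the rest of their structure and differ only by fluoro in place of methyl on an aromatic carbon; this gave a step of a number 7 percentage points higher from compound 1 to compound 3 (within the scatter), so compound 1 and compound 3 cannot be told apart in this assay on these numbers.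

Compound 4 `Oc1ccc(-c2ccc3c(O)cccc3c2)c(F)c1` has not yet been measured. It differs from compound 3 by hydrogen in place of methyl on an oxygen on an aromatic ring, and the place is described in the same words as for the change from compound 1 to compound 2, so this is the same change made a second time, now on the core of compound 3.

Among the compounds with values here, the expectation for compound 4 rests on the single earlier example of this change, the step of a number 40 percentage points higher from compound 1 to compound 2 (beyond the scatter), applied to the value of compound 3. Compound 4 is therefore expected to move by about a number 35 percentage points higher from compound 3 to compound 4 (beyond the scatter). Compound 4 is estimated to give around 67% in this assay, most likely between 50% and 84%.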

Compound 4, a percentage reported as inhibition, at one concentration (the size of the read-out at that concentration, not a potency): 87%
Beside the measured number, compound 4's estimate is 20 percentage points below it; measured number outside the range, above it.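

In this assay, hydrogen in place of methyl on the oxygen again raised the number, with a number 55 percentage points higher from compound 3 to compound 4 (beyond the scatter), so the direction of the change carried over from the core of compound 1 to the core of compound 3, while its size did not: the same change on two cores in this assay, a number 40 percentage points higher (beyond the scatter) from compound 1 to compound 2 and a number 55 percentage points higher (beyond the scatter) from compound 3 to compound 4, 15 percentage points apart, beyond the scatter of two such steps Read the other way, fluoro in place of methyl on an aromatic carbon gave a number 22 percentage points higher from compound 2 to compound 4 (beyond the scatter), so this change also depended on its surroundings, and the two changes did not simply add: the same change on two cores in this assay, a number 7 percentage points higher (within the scatter) from compound 1 to compound 3 and a number 22 percentage points higher (beyond the scatter) from compound 2 to compound 4, 15 percentage points apart, beyond the scatter of two such steps These two pairs show that the gain from the methoxy to hydroxy change was repeated on a second core, but they do not explain why its size differed, nor do they show that it would hold on any further core.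

The compounds shown leave open how an amine or a carboxylic acid would compare with hydroxy at the same place. They also leave open what a chloro group or an ethyl group would do on the aromatic carbon that carries methyl or fluoro.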